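Working notes on the shared core, compound 4 pending

A few compounds are considered here, and "the series" means these few. Any claim that something is new, unique, unknown or untested is made for them only; others in the source may bear on it.

Measured so far:
- compound 1, `Cc1ccc(-c2ccc3[nH]c(=O)nc(-c4ccccc4)c3c2)cn1`: in an ADME assay on L6 cells (Rattus norvegicus) for cytotoxicity, read by fluorescence and resazurin assay, with a stated time of 72 h (on this read-out lower numbers stand for an effect already at smaller amounts and higher numbers for an effect only at larger amounts of compound), compound 1 stops at the limit > 50000 nM
- compound 2, `O=c1nc(-c2ccccc2)c2cc(-c3ccccc3)ccc2[nH]1`: in this assay compound 2 also stops at the limit > 50000 nM
- compound 3, `O=c1nc(-c2ccccc2)c2cc(-c3ccccc3F)ccc2[nH]1`: in this assay compound 3 gives 55800 nM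

Among the compounds with values here, compound 3 thus stands as the only actual number among the three; the other two entries are limits, not numbers, which is the limit of > 50000 nM in this assay, at which 2 of the 3 values shown sit. The steps among the measured compounds are a step that the two limits leave unreadable from compound 1 to compound 2, a step that the limit leaves unreadable from compound 1 to compound 3 and a step that the limit leaves unreadable from compound 2 to compound 3, and none of them can be sized because of the limit of > 50000 nM in this assay, at which 2 of the 3 values shown sit.

Compound 4, `N#Cc1ccc(-c2ccc3[nH]c(=O)nc(-c4ccccc4)c3c2)cc1`, is not yet measured. It differs from compound 3 in one place: 4-cyanophenyl in place of 2-fluorophenyl on an aromatic carbon. The two measured steps that end at compound 3 bear on this change, but both are unreadable, so they give no direction and no size. The expectation in this assay is therefore no step beyond the scatter, with a real chance that only a limit is reported again. Compound 4 is estimated at 60000 nM, within 25000 nM to 150000 nM. The expected step is a 1.1-fold higher number from compound 3 to compound 4 (0.03 log units; within the scatter).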

Compound 4, half-maximal effective concentration: > 50000 nM
Compound 4: only a limit was reported (the forecaster's own chance of this, stated with the estimate: 60%); the middle value does not contradict the limit.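

No new step can be read between compound 4 and compound 1, compound 2 or compound 3, because the values stop at a limit and are not numbers: the limit of > 50000 nM in this assay, at which 3 of the 4 values shown sit.

The compounds shown leave open whether 4-cyanophenyl, phenyl or 6-methylpyridin-3-yl differs in effect from 2-fluorophenyl on the shared core.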